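Swapping naphthalen-1-yl for phenyl in compound 2

The compounds below may be only part of what the source reports. "The series", "measured", "known", "first", "only" and "open" are said of these compounds alone.

Of the compounds shown here, three have been measured in a functional assay on THP-1 cells (Homo sapiens) for inhibition, read by sulforhodamine B assay, with a stated time of 48 h, tested at 50 uM; on this read-out lower numbers stand for less inhibition of growth and higher numbers for more inhibition of growth at the one concentration tested. Compound 1 (`COc1ccc(/C=C/C(=O)/C=C/c2ccc(OCc3cn(CCCCOc4cc(=O)oc5ccccc45)nn3)c(OC)c2)cc1OC`) gives 59%, compound 2 (`COc1cc(/C=C/C(=O)/C=C/c2cccc3ccccc23)ccc1OCc1cn(CCCCCOc2cc(=O)oc3ccccc23)nn1`) gives 44% and compound 3 (`COc1cc(/C=C/C(=O)/C=C/c2cc(OC)c(OC)c(OC)c2)ccc1OCc1cn(CCOc2cc(=O)oc3ccccc23)nn1`) gives 99%. Compound 2 therefore stands lowest of the three, beyond the scatter from both of the others.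

Compound 4 (`COc1cc(/C=C/C(=O)/C=C/c2ccccc2)ccc1OCc1cn(CCCCCOc2cc(=O)oc3ccccc23)nn1`) has not yet been measured in this assay. It differs from compound 2 in one place: phenyl in place of naphthalen-1-yl on a double-bonded chain carbon bound to a double-bonded chain carbon. This puts phenyl in place of naphthalen-1-yl on a double-bonded chain carbon bound to a double-bonded chain carbon.

Among the measured compounds shown here, no measured pair isolates this change, so the data give no direct size for it. For the measured compounds named here, the only guide is that compound 2, the one measured compound carrying naphthalen-1-yl, reads 44%, under the other two, although those also differ from it elsewhere.

A small upward step is expected, a number 6 percentage points higher from compound 2 to compound 4 (within the scatter), probably not beyond the scatter. For compound 4 the estimated value is 50%, with an expected range from 30% to 72%.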

Compound 4, percent growth inhibition at one concentration: 26%
For compound 4 the middle estimate is 24 percentage points above the measured one; the measured number lies below the stated range.
By their numbers in this assay, from the lowest: compound 4; then compound 2; then compound 1; then compound 3.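

Among the compounds shown here, this is the first direct size for this change: in this assay, phenyl in place of naphthalen-1-yl on a double-bonded chain carbon bound to a double-bonded chain carbon gives a number 18 percentage points lower from compound 2 to compound 4 (beyond the scatter) with the rest of the structure held fixed. The earlier compounds shown here formed no pair that differed in one place, so they could not show the direction of this change, which here favours the larger naphthalen-1-yl over phenyl. Nothing measured here explains why the step runs this way.

From the compounds shown here alone, it remains open whether the step keeps its size and direction when the rest of the structure differs, as in the shared core with a shorter chain. Also open, going by these compounds, is how other groups at this place would read, such as naphthalen-2-yl, a phenyl bearing an amine, or a phenyl bearing a carboxylic acid.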